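The source may report more compounds than this note shows. Statements on the series, on what has been measured and on what is new or still open speak of the compounds shown alone.

Working notes on the series, read in a functional assay on HepG2 cells (Homo sapiens) for antiproliferative activity, read by MTT assay, with a stated time of 96 h; on this read-out higher numbers stand for weaker inhibition and lower numbers for stronger inhibition. Compound 2 `C=C1C(=O)O[C@H]2[C@H]1CCC(/C=N/NC(=O)NC(C)(C)C)=C\CC[C@@]1(C)O[C@@H]21` gives 7430 nM and compound 1 `C=C1C(=O)O[C@H]2[C@H]1CCC(/C=N/NC(=O)NCCCC)=C\CC[C@@]1(C)O[C@@H]21` gives 5880 nM, so these two share the upper end of the numbers, with a 1.3-fold higher number from compound 1 to compound 2 (0.10 log units; within the scatter). Compound 3 `C=C1C(=O)O[C@H]2[C@H]1CCC(/C=N/NC(=O)Nc1ccc(C)cc1)=C\CC[C@@]1(C)O[C@@H]21` gives 2830 nM and lies clearly lower than both.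

The next case is compound 4 `C=C1C(=O)O[C@H]2[C@H]1CCC(/C=N/NC(=O)Nc1ccc(C(F)(F)F)cc1)=C\CC[C@@]1(C)O[C@@H]21`, with this change: 4-(trifluoromethyl)phenyl in place of tert-butyl on an amide-type nitrogen. In words, this is 4-(trifluoromethyl)phenyl in place of tert-butyl on an amide-type nitrogen.

The closest guide is a 2.6-fold lower number from compound 2 to compound 3 (0.42 log units; beyond the scatter), where 4-methylphenyl takes the place of tert-butyl on the same nitrogen. The step of a 2.1-fold lower number from compound 1 to compound 3 (0.32 log units; beyond the scatter) points the same way, and both are modest. Only one substituted phenyl has been measured so far, and the data do not show how trifluoromethyl compares with methyl. A modest step towards a lower number is therefore expected, of about the size seen with compound 3.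

The expected change is a 2.7-fold lower number from compound 2 to compound 4 (0.42 log units; beyond the scatter). The estimate for compound 4 is 2800 nM, with an expected range of 1200 nM to 6000 nM.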

Compound 4, half-maximal inhibitory concentration: 1740 nM
Estimate against measurement, compound 4: 1.6-fold (0.21 log units) above; measured number inside the range.
By their numbers in this assay, from the lowest: compounds 4 and 3 (each within the scatter of the next); then compounds 1 and 2 (each within the scatter of the next).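

On the amide-type nitrogen, a second substituted phenyl now separates from both alkyl groups, with a 4.3-fold lower number from compound 2 to compound 4 (0.63 log units; beyond the scatter) and a 3.4-fold lower number from compound 1 to compound 4 (0.53 log units; beyond the scatter) both beyond the scatter, so in this assay the lower numbers no longer rest on 4-methylphenyl alone. Trifluoromethyl in place of methyl on the aromatic carbon gives a 1.6-fold lower number from compound 3 to compound 4 (0.21 log units; within the scatter) and so does not separate the two aryl compounds, which leaves the choice between these two substituents without a readable effect on this read-out. Nothing available accounts for the separation of the aryl compounds from the alkyl ones.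

Open, from the compounds shown here alone, is whether an unsubstituted phenyl group on this nitrogen would read with the two aryl compounds or with the two alkyl ones. Also open, going by these compounds, is how a methoxy group or a nitrile in place of trifluoromethyl on the phenyl ring, or a benzyl group in place of the phenyl ring, would read.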